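Working notes: from compound 2 to compound 4

The source may report more compounds than this note shows. Statements on the series, on what has been measured and on what is new or still open speak of the compounds shown alone.

Measured in a physicochemical assay for solubility, at pH 7.4; on this read-out lower numbers stand for lower solubility and higher numbers for higher solubility:
- compound 1 (`NS(=O)(=O)c1ccc(S(=O)(=O)CCO)c(F)c1`): 3300 ug/mL
- compound 2 (`NS(=O)(=O)c1ccc(SCCCO)s1`): 9500 ug/mL
- compound 3 (`COCC(=O)OCCCS(=O)(=O)c1ccc(S(N)(=O)=O)s1`): 970 ug/mL

Compound 2 stands highest of these three, and its gaps to compound 1 and to compound 3 both lie beyond the usual scatter. Compound 4 (`NS(=O)(=O)c1ccc(SCCCCO)s1`) has not yet been measured. The structural change is hydroxymethyl in place of hydroxy on a saturated chain carbon, three bonds along the chain from a sulfur. Cut one bond further out, the same difference reads 3-hydroxypropyl to 4-hydroxybutyl.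

Going by the values given here, no measured pair differs in one place only, so the series offers no direct precedent for this change. With compound 2 at 9500 ug/mL, the top of the measured range, a moderate fall in this assay is expected rather than a rise, probably a little beyond the scatter. The estimated change is a 2.4-fold lower number from compound 2 to compound 4 (0.38 log units; beyond the scatter). For compound 4 the estimate is 4000 ug/mL, with an expected range from 1500 ug/mL to 9000 ug/mL.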

Compound 4, solubility: 9300 ug/mL
Estimate against measurement, compound 4: 2.3-fold (0.37 log units) below; measured number outside the range, above it.
By their numbers in this assay, from the lowest: compound 3; then compound 1; then compounds 4 and 2 (each within the scatter of the next).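

Going by these compounds alone, the first one-place step reads, in this assay, as a 1.0-fold lower number from compound 2 to compound 4 (0.01 log units; within the scatter), for hydroxymethyl in place of hydroxy on a saturated chain carbon, three bonds along the chain from a sulfur. At this position, then, the read-out does not separate 3-hydroxypropyl from 4-hydroxybutyl, and compound 4 stands level with compound 2 at the top of the measured range. No supporting measurement bears on this result, so it stands as an observation without an explanation.

This single step does not show whether a longer chain with a terminal hydroxy would read the same way, or how an amine or a carboxylic acid at the chain end would compare. It also leaves open whether the same extension would give a similar step with a sulfonyl in place of the chain sulfur.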